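Swapping the anilide ring: a para trifluoromethyl replaces ortho bromine

A few compounds are considered here, and "the series" means these few. Any claim that something is new, unique, unknown or untested is made for them only; others in the source may bear on it.

Compound 1 `O=C(CSc1nc(Nc2ccccc2)c2ccccc2n1)Nc1ccccc1Br` was tested in a functional assay on PC-3 cells (Homo sapiens) for inhibition, read by MTT assay, with a stated time of 72 h; on this read-out lower numbers stand for stronger inhibition and higher numbers for weaker inhibition. In this assay, for the measured compounds named here, compound 1 gives 19800 nM, while the only other measured compound, compound 2 `O=C(CSc1nc(Nc2ccccc2)c2ccccc2n1)Nc1ccc(Cl)cc1`, gives 12900 nM, so the two sit within the scatter of each other. Compound 3 `O=C(CSc1nc(Nc2ccccc2)c2ccccc2n1)Nc1ccc(C(F)(F)F)cc1` differs from compound 1 in one place: 4-(trifluoromethyl)phenyl in place of 2-bromophenyl on an amide-type nitrogen. Going by the values given here, the one measured step that bears on this is a 1.5-fold lower number from compound 1 to compound 2 (0.19 log units; within the scatter), which stays within the scatter. A step of similar small size is therefore expected, a 1.7-fold lower number from compound 1 to compound 3 (0.22 log units; within the scatter). Compound 3 is estimated at 12000 nM, with a range from 5000 nM to 30000 nM.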

Compound 3, half-maximal inhibitory concentration: 10400 nM
Compound 3: the middle estimate sits 1.2-fold (0.06 log units) above what was measured; the measured number falls inside the stated range.
By their numbers in this assay, from the lowest: compounds 3, 2 and 1 (each within the scatter of the next).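

Putting 4-(trifluoromethyl)phenyl in place of 2-bromophenyl on the amide-type nitrogen leaves the result close (a 1.9-fold lower number from compound 1 to compound 3 (0.28 log units; within the scatter)), and so does trifluoromethyl in place of chloro on an aromatic carbon (a 1.2-fold lower number from compound 2 to compound 3 (0.09 log units; within the scatter)). The larger group, with 10 heavy atoms against 7, therefore adds a third ring at this place that cannot be told apart from the other two. As far as these compounds go, whether an amine or a carboxylic acid on this ring would give a step beyond the scatter stays open. No measurement shown offers a reason for this closeness.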